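Terphenylpyridine triols: effect of hydroxyl placement on cytotoxicity

The compounds below may be only part of what the source reports. "The series", "measured", "known", "first", "only" and "open" are said of these compounds alone.

Measured so far:
compound 1 `Oc1ccc(-c2cc(-c3cccc(O)c3)cc(-c3cccc(O)c3)n2)cc1`: 3090 nM
compound 2 `Oc1ccc(-c2cc(-c3ccccc3O)cc(-c3ccccc3O)n2)cc1`: 8240 nM
compound 3 `Oc1cccc(-c2cc(-c3ccccc3O)cc(-c3ccccc3O)n2)c1`: 3390 nM

All three were tested in a functional assay on HCT-15 cells (Homo sapiens) for cytotoxicity, read by CCK-8 assay, with a stated time of 4 days; on this read-out higher numbers stand for weaker inhibition and lower numbers for stronger inhibition. Compound 1 gives the lowest number, and compound 3 lies within the scatter of it; compound 2 sits beyond both. The difference between the cores of compound 1 and compound 3 is not broken down here. From compound 3 to compound 2 one change is made, (4-hydroxyphenyl in place of 3-hydroxyphenyl on an aromatic carbon), and it produced a 2.4-fold higher number from compound 3 to compound 2 (0.39 log units; beyond the scatter). Compound 4 `Oc1ccc(-c2cc(-c3ccc(O)cc3)nc(-c3cccc(O)c3)c2)cc1` is not yet measured; it arises from compound 1 by 4-hydroxyphenyl in place of 3-hydroxyphenyl on an aromatic carbon, the same kind of change, though here the place is opposite the ring nitrogen and meta to a 3-hydroxyphenyl group and a 4-hydroxyphenyl group, whereas in compound 3 it is next to the ring nitrogen and meta to two 2-hydroxyphenyl groups. For compound 4 a step of similar size to the one just described is expected, namely a 2.1-fold higher number from compound 1 to compound 4 (0.32 log units; beyond the scatter), resting on that single precedent. Compound 4 is therefore estimated at 6500 nM, plausibly between 2500 nM and 16000 nM.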

Compound 4, half-maximal inhibitory concentration: 3520 nM
Compound 4: the middle estimate sits 1.8-fold (0.27 log units) above what was measured; low and high end bracket the measured number.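

On the core of compound 1, 4-hydroxyphenyl in place of 3-hydroxyphenyl on an aromatic carbon gives a 1.1-fold higher number from compound 1 to compound 4 (0.06 log units; within the scatter) in this assay. The same change thus reads beyond the scatter on one core and within it on the other, yet the two steps cannot be separated: the same change on two cores in this assay, a 2.4-fold higher number (0.39 log units; beyond the scatter) from compound 3 to compound 2 and a 1.1-fold higher number (0.06 log units; within the scatter) from compound 1 to compound 4, 2.1-fold (0.33 log units) apart, within the scatter of two such steps. The pair therefore does not show that the change keeps one size across cores, nor that the core alters its size, and two steps fix no size for a further core.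

All compounds shown carry only hydroxyphenyl groups, so what the hydroxyl itself contributes stays open. A methoxy group, an amine or a carboxylic acid in its place would address this.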